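The compounds below may be only part of what the source reports. "The series", "measured", "known", "first", "only" and "open" are said of these compounds alone.

Working notes on the piperidine series.

Compound 3 `COc1cc(C#N)ccc1OCCCN1CCC(C(c2ccc(F)cc2)c2ccc(F)cc2)CC1` carries the lowest number among the three measured compounds in a functional assay (aorta) with Oryctolagus cuniculus as the target (a higher number here means weaker binding, a lower number tighter binding), where compound 3 gives 2 nM. The nearest measured compound is compound 1 `COc1ccc(C(c2ccc(OC)cc2)C2CCN(CCCOc3ccc(C(C)=O)cc3OC)CC2)cc1`, which in this assay gives 10 nM; the gap from compound 3 to compound 1 is beyond the scatter. Furthest is compound 2 `COc1cc(C(C)=O)ccc1OCCCN1CCC(C(N)(c2ccc(F)cc2)c2ccc(F)cc2)CC1`, which in this assay gives 31.6 nM, again a gap beyond the scatter from compound 3. No two of these three compounds differ in one place only, so no single step can be read off among them.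

The next compound, compound 4 `Fc1ccc(C(c2ccc(F)cc2)C2CCN(CCCOc3ccc4ccccc4c3)CC2)cc1`, has not yet been measured in this assay. It differs from compound 3 in one place: naphthalen-2-yl in place of 4-cyano-2-methoxyphenyl on an oxygen on a saturated carbon. The change removes the nitrile and the methoxy group on that ring and brings in a second fused ring in their stead. Among the measured compounds shown here, nothing among the measured compounds isolates the effect of this exchange, since compounds 1 and 2 also vary elsewhere.

The expectation is a modest loss, with the step from compound 3 to compound 4 estimated at a 3.0-fold higher number from compound 3 to compound 4 (0.48 log units; beyond the scatter), possibly within the scatter. For compound 4 the estimate in this assay is 6 nM, with a range from 1.5 nM to 30 nM.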

Compound 4, dissociation constant: 7.94 nM
Compound 4: middle estimate off by 1.3-fold (0.12 log units), on the low side; the measured number falls inside the stated range.
By their numbers in this assay, from the lowest: compound 3; then compounds 4 and 1 (each within the scatter of the next); then compound 2.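

In this assay, exchanging 4-cyano-2-methoxyphenyl for naphthalen-2-yl on an oxygen on a saturated carbon gives a modest step that lies beyond the scatter (a 4.0-fold higher number from compound 3 to compound 4 (0.60 log units; beyond the scatter)). The nitrile, the methoxy group and both hydrogen-bond acceptors of the leaving group are therefore not needed for a nanomolar number, as compound 4 gives 7.94 nM with a carbon-only group of the same heavy-atom count, though the exchange does carry a real cost at this position. No supporting measurement on hand accounts for the size of this step.

Among the compounds shown here, the single exchange removes the nitrile and the methoxy group and adds a second fused ring all at once, so the share of each in the step remains unresolved. From the compounds shown here alone, a single methoxy group on the ring, or an amine or a carboxylic acid in place of the nitrile, would help to separate these contributions, and whether naphthalen-2-yl behaves the same way with the other groups on the shared core, such as the methoxy-bearing aryl rings of compound 1, also remains open.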